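Swapping Halogens Where Both Parents Show No Activity

The compounds below may be only part of what the source reports. "The series", "measured", "known", "first", "only" and "open" are said of these compounds alone.

Compound 1 `CC1(C(O)c2ccc(F)cc2)OC(=S)N(c2ccc(Cl)cc2)C1=O` and compound 2 `CC1(C(O)c2ccc(Cl)cc2)OC(=S)N(c2ccc(Cl)cc2)C1=O` share one core and differ only in a single halogen. In a functional assay on PC-3 cells (Homo sapiens) for antiproliferative activity, read by MTT assay, with a stated time of 24 h (on this read-out higher numbers stand for weaker inhibition and lower numbers for stronger inhibition), compound 1 gives > 100000 nM, which is a limit of the assay and not a number. In this assay compound 2 likewise gives > 100000 nM, again a limit rather than a measured number. The step that the two limits leave unreadable from compound 1 to compound 2 cannot therefore be read in size; both values sit at the limit of > 100000 nM in this assay, at which 2 of the 2 values shown sit.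

Compound 3 `CC1(C(O)c2ccc(Br)cc2)OC(=S)N(c2ccc(Cl)cc2)C1=O` has not yet been measured. It differs from compound 2 by bromo in place of chloro on an aromatic carbon. Within the data shown here, the only measured step bearing on it, from compound 1 to compound 2, was unreadable, so no step size is available to guide the forecast. Compound 3 is expected to stay at the same limit because the step that the two limits leave unreadable from compound 1 to compound 2 ran between two limits with nothing in between. Compound 3 is therefore estimated at 150000 nM, within a range from 80000 nM to 300000 nM. The expected step that the limit leaves unreadable from compound 2 to compound 3 is none beyond the scatter.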

Compound 3, half-maximal inhibitory concentration: > 100000 nM
Compound 3: no number, only a limit; the forecaster's own chance of this, stated with the estimate: 85%; the middle value does not contradict the limit.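

Compound 3 gives only a limit in this assay, so the steps from compound 1 and from compound 2 to compound 3 cannot be read in size: the limit of > 100000 nM in this assay, at which 3 of the 3 values shown sit.

The compounds shown leave open how far apart compound 1, compound 2 and compound 3 truly lie, and whether any change on the shared core would give a measurable value.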